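The source may hold more compounds than are shown below. What is called first, only, known or untested is meant among the compounds shown, and "the series" means these compounds.

Working notes on the series. Compound 1 is `O=C(/C=C/c1ccc(OCCCCCO[N+](=O)[O-])c(O)c1)OCCCCCO[N+](=O)[O-]`, compound 2 is `O=C(/C=C/c1ccc(OCCCCCCO[N+](=O)[O-])c(O)c1)OCCCCCCO[N+](=O)[O-]`, compound 3 is `COc1cc(/C=C/C(=O)OCCCCCO[N+](=O)[O-])ccc1OCCCCCO[N+](=O)[O-]`, and compound 4, not yet measured, is `COc1cc(/C=C/C(=O)OCCCCCCO[N+](=O)[O-])ccc1OCCCCCCO[N+](=O)[O-]`. The difference between the core of compound 1 and the core of compound 2 is not broken down here. Compound 3 arises from compound 1 by methyl in place of hydrogen on an oxygen on an aromatic ring. Compound 4 arises from compound 2 by methyl in place of hydrogen on an oxygen on an aromatic ring. The two place descriptions read word for word alike, so it is the same change made on two cores.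

In a functional assay on M14 cells (Homo sapiens) for cytotoxicity, read by resazurin assay, with a stated time of 72 h (a higher number here means a weaker inhibitor, a lower number a stronger inhibitor), compound 1 gives > 50000 nM, which is a limit of the assay and not a number. In this assay compound 2 gives > 50000 nM, again a limit. In this assay compound 3 gives > 50000 nM, also a limit. The step that the two limits leave unreadable from compound 1 to compound 3 cannot be read because both ends rest at the limit of > 50000 nM in this assay, at which 3 of the 3 values shown sit. Whether the change from hydroxy to methoxy moves potency at all is therefore unknown on the core of compound 1, and nothing on the core of compound 2 speaks against the same outcome.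

For compound 4 the expected step is a step that the limit leaves unreadable from compound 2 to compound 4, an expectation that rests on the limit of > 50000 nM in this assay, at which 3 of the 3 values shown sit, and on the unreadable a step that the two limits leave unreadable from compound 1 to compound 3. Compound 4 is thus expected near 60000 nM, somewhere between 20000 nM and 200000 nM, with a limit rather than a number the most likely report.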

Compound 4, half-maximal inhibitory concentration: > 50000 nM
Compound 4 gave a limit, no number (the forecaster's own chance of this, stated with the estimate: 85%); the middle value lies beyond the limit too.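

In this assay compound 4 gives > 50000 nM, a limit of the assay and not a number. The step from compound 2 to compound 4 therefore cannot be read, and no new step results: the limit of > 50000 nM in this assay, at which 4 of the 4 values shown sit.

The compounds shown leave open whether hydroxy to methoxy changes potency at all on either core, and at what concentration any of the four would reach half-maximal inhibition.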